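Ortho-fluorine on two aryl rings of a thieno core

The source may hold more compounds than are shown below. What is called first, only, known or untested is meant among the compounds shown, and "the series" means these compounds.

Measured compounds:
compound 1, `NC(=O)c1c(NC(=O)c2ccccc2Cl)sc2c1CCN(C(=S)Nc1ccccc1)C2`, 46700 nM
compound 2, `NC(=O)c1c(NC(=O)c2ccccc2Cl)sc2c1CCN(C(=S)Nc1ccccc1F)C2`, 28700 nM
compound 3, `NC(=O)c1c(NC(=O)c2ccccc2)sc2c1CCN(C(=S)Nc1ccccc1Cl)C2`, a limit only

Compound 1 and compound 2 were tested in a functional assay on HeLa cells (Homo sapiens) for antiproliferative activity, with a stated time of 24 h; on this read-out higher numbers stand for weaker inhibition and lower numbers for stronger inhibition. Their difference is fluoro in place of hydrogen on an aromatic carbon, which reads as anilino to (2-fluorophenyl)amino, and the measured step is a 1.6-fold lower number from compound 1 to compound 2 (0.21 log units; within the scatter). Compound 3 was also run in this assay and gave > 50000 nM, which is a limit of the assay, (the limit of > 50000 nM in this assay, at which 1 of the 3 values shown sits), so no number is known for it. The difference between the core of compound 3 and the core of compound 1 is not broken down here.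

Compound 4, `NC(=O)c1c(NC(=O)c2ccccc2F)sc2c1CCN(C(=S)Nc1ccccc1Cl)C2`, is not yet measured. It differs from compound 3 by fluoro in place of hydrogen on an aromatic carbon, which reads as benzamido to ((2-fluorophenyl)carbonyl)amino; the same kind of change, on another ring, is that from compound 1 to compound 2. Since that earlier step, a 1.6-fold lower number from compound 1 to compound 2 (0.21 log units; within the scatter), stayed within the scatter, the step from compound 3 to compound 4 is expected to be about an at least 1.1-fold lower number from compound 3 to compound 4 (0.04 log units; that floor lies within the scatter). Compound 4 is therefore estimated at 45000 nM in this assay, between 20000 nM and 100000 nM, with a real chance that only a limit is reported again.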

Compound 4, half-maximal inhibitory concentration: 19400 nM
Compound 4: middle estimate off by 2.3-fold (0.37 log units), on the high side, outside the stated range (below it).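

In this assay, fluoro in place of hydrogen on an aromatic carbon of the benzamido ring gave an at least 2.5-fold lower number from compound 3 to compound 4 (0.41 log units; beyond the scatter). Set beside the same change on the other ring and core, this neither shows that the change carries over with the same size nor shows that its size differs: the same change on two cores in this assay, a 1.6-fold lower number (0.21 log units; within the scatter) from compound 1 to compound 2 and an at least 2.5-fold lower number (0.41 log units; beyond the scatter) from compound 3 to compound 4; the limit leaves it open whether they differ. On these data alone, compound 3 stands only at a limit, so the full size of its step remains unknown, and two pairs cannot establish a rule for the series: the limit of > 50000 nM in this assay, at which 1 of the 4 values shown sits.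

The compounds shown leave open how a methoxy group or an amine would compare with fluoro on the same aromatic carbon. They also leave open whether compound 4 would keep its value with a methyl group in place of the chloro on its other ring.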